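The source may report more compounds than this note shows. Statements on the series, on what has been measured and on what is new or still open speak of the compounds shown alone.

Compound 1 `Cc1cc(NC(=O)Nc2ccc(O)cc2)c2ccccc2n1`: in a physicochemical assay for solubility, at pH 7.4 (a lower number here means a less soluble compound, a higher number a more soluble compound), compound 1 gives 100 nM.
Compound 2 `Cc1cc(NC(=O)Nc2ccc(Cl)cc2)c2ccccc2n1`: in this assay compound 2 gives 1400 nM.
Compound 3 `Cc1cc(NC(=O)Nc2ccccc2[N+](=O)[O-])c2ccccc2n1`: in this assay compound 3 gives 200 nM.

Among these three numbers, compound 3 stands second highest. Its nearest neighbour is compound 1, whose value lies within the scatter of that of compound 3, so the two cannot be ordered; compound 2 stands furthest away, beyond the scatter. Going by the values given here, the only step between compounds that differ in a single place is a 14-fold higher number from compound 1 to compound 2 (1.15 log units; beyond the scatter), a large change.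

Compound 4 `Cc1cc(NC(=O)Nc2ccccc2N)c2ccccc2n1` differs from compound 3 in one place: amino in place of nitro on an aromatic carbon. Among the compounds with values here, no measured step covers this exchange; the single step available concerns chloro in place of hydroxy, a different pair of groups, and so gives no direct guidance. With nothing in the data pointing either way, compound 4 is expected to show a 1.3-fold higher number from compound 3 to compound 4 (0.10 log units; within the scatter), that is, no step beyond the scatter. The estimate for compound 4 in this assay is 250 nM, with a range from 80 nM to 800 nM to reflect the uncertainty of an uncharted change.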

Compound 4, solubility: 51800 nM
Compound 4: the middle estimate sits 210-fold (2.32 log units) below what was measured, and the stated range ends below it.
By their numbers in this assay, from the lowest: compounds 1 and 3 (each within the scatter of the next); then compound 2; then compound 4.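

In this assay, going by these compounds alone, the exchange of nitro for amino on an aromatic carbon, ortho to a large group, gives a 260-fold higher number from compound 3 to compound 4 (2.41 log units; beyond the scatter) and so exceeds the one earlier step, a 14-fold higher number from compound 1 to compound 2 (1.15 log units; beyond the scatter), which concerned chloro and hydroxy. Measured against the other two compounds, 2-aminophenyl in place of 4-chlorophenyl gives a 37-fold higher number from compound 2 to compound 4 (1.57 log units; beyond the scatter) and 2-aminophenyl in place of 4-hydroxyphenyl gives a 520-fold higher number from compound 1 to compound 4 (2.71 log units; beyond the scatter), which leaves compound 4 with the highest number of the four, beyond the scatter of each of the others. Nothing available accounts for the size of these steps.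

The compounds shown leave open whether the large step belongs to amino itself, since no methylamino or acetamido group stands in that place. They also leave open what a carboxylic acid or a longer aminoalkyl chain would give there.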